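A few compounds are considered here, and "the series" means these few. Any claim that something is new, unique, unknown or untested is made for them only; others in the source may bear on it.

Measured so far in a functional assay on HeLa cells (Homo sapiens) for inhibition; on this read-out higher numbers stand for weaker inhibition and lower numbers for stronger inhibition:
compound 1 `O=C1O/C(=C\Cn2cc(C(F)(F)F)c(=O)[nH]c2=O)C(OCc2ccccc2)=C1OCc1ccccc1` gives 20000 nM
compound 2 `O=C1O/C(=C\Cn2cnc3c(-n4cccc4)ncnc32)C(OCc2ccccc2)=C1OCc1ccccc1` gives 70000 nM

Of these two numbers, compound 1 stands at the lower one, which here means the stronger inhibition; compound 2 sits above it by a gap beyond the usual scatter. Compound 3 `O=C1O/C(=C\Cn2cc(I)c(=O)[nH]c2=O)C(OCc2ccccc2)=C1OCc1ccccc1` has not yet been measured. It differs from compound 1 in one place: iodo in place of trifluoromethyl on an aromatic carbon. Within the data shown here, no measured pair shows a change of this kind, so nothing sets the size of the step from measured data. The step of no change at the digits printed from compound 1 to compound 3 (within the scatter) is expected to be small, within the scatter, with no clear direction. Compound 3 is expected to give 20000 nM, in a range from 7000 nM to 60000 nM.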

Compound 3, half-maximal inhibitory concentration: 30000 nM
Compound 3: middle estimate off by 1.5-fold (0.18 log units), on the low side; the measured number falls inside the stated range.
By their numbers in this assay, from the lowest: compounds 1 and 3 (each within the scatter of the next); then compound 2.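

Among these compounds, compound 1 and compound 3 form the first pair that isolates this position on the six-membered ring. In this assay, replacing trifluoromethyl with iodo gives a 1.5-fold higher number from compound 1 to compound 3 (0.18 log units; within the scatter) and so leaves the two compounds indistinguishable, even though one heavy atom takes the place of four. No available measurement offers an explanation for this result. On these data alone, whether an amine, a carboxylic acid or a longer carbon chain at this position would keep the read-out in the same range remains open.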